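The compounds below may be only part of what the source reports. "The series", "measured", "known", "first", "only" and "open" are said of these compounds alone.

Measured in a functional assay on A549 cells (Homo sapiens) for inhibition, read by sulforhodamine B assay; a higher number here means a weaker inhibitor of growth, a lower number a stronger inhibitor of growth:
- compound 1 `FC(F)(F)c1ccc(-c2ccc(-c3ccc(-c4nc5ccccc5[nH]4)cc3)cc2)cc1`: 36600 nM
- compound 2 `CN(C)c1ccc(-c2ccc(-c3ccc(-c4nc5ccccc5[nH]4)cc3)cc2)cc1`: 30100 nM
- compound 3 `Oc1cccc2[nH]c(-c3ccc(-c4ccc(-c5ccc(C(F)(F)F)cc5)cc4)cc3)nc12`: 3610 nM

Compound 3 has the lowest number of the three, well under both other compounds. Compound 4 `CN(C)c1ccc(-c2ccc(-c3ccc(-c4nc5c(O)cccc5[nH]4)cc3)cc2)cc1` keeps the hydroxy of compound 3 but has dimethylamino in place of trifluoromethyl on an aromatic carbon, para to a large group: dimethylamino in place of trifluoromethyl on an aromatic carbon. The same swap without the hydroxy gave a 1.2-fold lower number from compound 1 to compound 2 (0.08 log units; within the scatter). Adding the hydroxy gave a 10-fold lower number from compound 1 to compound 3 (1.01 log units; beyond the scatter), a large step, and compound 4 retains that group. Within the data shown here, only this one pair shows the swap, and it has not been measured with the hydroxy present. In this assay, no change beyond the scatter is therefore expected, and the expected step is a 1.2-fold lower number from compound 3 to compound 4 (0.08 log units; within the scatter). For compound 4 the estimate is 3000 nM, with an expected range of 1300 nM to 7500 nM.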

Compound 4, concentration for 50% growth inhibition: 7100 nM
Compound 4: the middle estimate sits 2.4-fold (0.37 log units) below what was measured, within the range that was stated.
By their numbers in this assay, from the lowest: compounds 3 and 4 (each within the scatter of the next); then compounds 2 and 1 (each within the scatter of the next).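

In this assay, dimethylamino in place of trifluoromethyl gives a 2.0-fold higher number from compound 3 to compound 4 (0.29 log units; within the scatter), so with the hydroxy present this position still tolerates the swap, and the step agrees with the one seen without the hydroxy: the same change on two cores in this assay, a 1.2-fold lower number (0.08 log units; within the scatter) from compound 1 to compound 2 and a 2.0-fold higher number (0.29 log units; within the scatter) from compound 3 to compound 4, 2.4-fold (0.38 log units) apart, within the scatter of two such steps

The hydroxy also still counts with dimethylamino at this position, giving a 4.2-fold lower number from compound 2 to compound 4 (0.63 log units; beyond the scatter), a step that agrees with the one seen with trifluoromethyl: the same change on two cores in this assay, a 10-fold lower number (1.01 log units; beyond the scatter) from compound 1 to compound 3 and a 4.2-fold lower number (0.63 log units; beyond the scatter) from compound 2 to compound 4, 2.4-fold (0.38 log units) apart, within the scatter of two such steps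

The compounds shown leave open whether a fluorine or a carboxylic acid at this position would move the number, and whether a methoxy in place of the hydroxy would keep the number low.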